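Dropping One Methoxy: From Compound 2 to Compound 3

The compounds below may be only part of what the source reports. "The series", "measured", "known", "first", "only" and "open" are said of these compounds alone.

Compound 1 `O=C(c1cccnc1)N1N=C(c2ccc(O)cc2)CC1c1ccccc1Cl`: 47700 nM
Compound 2 `COc1ccc(C2CC(c3ccc(O)cc3)=NN2C(=O)c2cccnc2)cc1OC`: 53600 nM

In an ADME assay on HepG2 cells (Homo sapiens) for cytotoxicity, read by MTT assay, with a stated time of 7 days (a higher number here means a weaker inhibitor, a lower number a stronger inhibitor), compound 1 gives 47700 nM and compound 2 gives 53600 nM. Compound 2 holds the higher of the two numbers, yet the step of a 1.1-fold higher number from compound 1 to compound 2 (0.05 log units; within the scatter) stays within the scatter, so the two compounds cannot be told apart here. Compound 3 `COc1ccc(C2CC(c3ccc(O)cc3)=NN2C(=O)c2cccnc2)cc1` differs from compound 2 by hydrogen in place of methoxy on an aromatic carbon. Within the data shown here, the only measured step, a 1.1-fold higher number from compound 1 to compound 2 (0.05 log units; within the scatter), exchanged a whole aryl group without a shift beyond the scatter, and no measured step removes a single methoxy. I therefore expect a step of a 1.0-fold higher number from compound 2 to compound 3 (0.01 log units; within the scatter), nothing beyond the scatter. For compound 3 the estimated value is 55000 nM, with an expected range from 25000 nM to 120000 nM.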

Compound 3, half-maximal inhibitory concentration: 42400 nM
Compound 3: middle estimate off by 1.3-fold (0.11 log units), on the high side; the range from low to high includes it.
By their numbers in this assay, from the lowest: compounds 3, 1 and 2 (each within the scatter of the next).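

In this assay, removing one methoxy, which turns 3,4-dimethoxyphenyl into 4-methoxyphenyl, gives a 1.3-fold lower number from compound 2 to compound 3 (0.10 log units; within the scatter) and so shows that this smaller edit on an aromatic carbon also leaves the compounds indistinguishable. Putting 4-methoxyphenyl in place of 2-chlorophenyl gives a 1.1-fold lower number from compound 1 to compound 3 (0.05 log units; within the scatter) and adds a third aryl group on the saturated ring carbon that cannot be separated from the other two. No supporting evidence is available to explain this sameness.

As far as these compounds go, whether an amine or a carboxylic acid on this aromatic carbon would shift the number beyond the scatter remains open.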